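Piperidinylmethyl in place of dimethylaminomethyl on a thiazole aminopyridine

The source may report more compounds than this note shows. Statements on the series, on what has been measured and on what is new or still open speak of the compounds shown alone.

Compound 1 `Cc1cccc(Nc2nc(-c3ccncc3)c(CN(C)C)s2)c1`: 16200 nM
Compound 2 `Cc1cccc(Nc2nnc(-c3ccncc3)o2)c1`: > 40000 nM; 40700 nM (2 entries)
Compound 3 `Cc1cccc(Nc2nc(-c3cnn4ccccc34)cs2)c1`: > 40000 nM; 40700 nM (2 entries)

In a functional assay on RCC4 cells (Homo sapiens) for inhibition, read by XTT assay, with a stated time of 4 days (on this read-out lower numbers stand for stronger inhibition and higher numbers for weaker inhibition), compound 1 gives 16200 nM. Among the measured compounds shown here, this is the only plain number among the three measured compounds. Compound 2 gives > 40000 nM; 40700 nM (2 entries). Compound 3 likewise gives > 40000 nM; 40700 nM (2 entries). For the measured compounds named here, compound 1 thus stands as the one compound with a number of its own, while compounds 2 and 3 sit at the edge of what this assay reports.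

Compound 4 `Cc1cccc(Nc2nc(-c3ccncc3)c(CN3CCCCC3)s2)c1` has not been measured. It differs from compound 1 in one place: piperidin-1-yl in place of dimethylamino on a saturated chain carbon bound to an aromatic carbon. Going by the values given here, no step between two measured compounds touches this part of the molecule, so no measured change gives a scale for it. The shared core of compound 1 and compound 4, with the aminopyridyl substitution, is kept intact, and the change is confined to the amine on the saturated chain carbon.

Compound 4 is therefore expected to land close to compound 1, with a step from a 1.4-fold lower number from compound 1 to compound 4 (0.13 log units; within the scatter) that stays within the usual scatter. The estimate for compound 4 in this assay is 12000 nM, with a range from 4000 nM to 40000 nM.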

Compound 4, half-maximal inhibitory concentration: 13200 nM
Compound 4: middle estimate off by 1.1-fold (0.04 log units), on the low side; the range from low to high includes it.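

In this assay, among the compounds shown here, putting piperidin-1-yl in place of dimethylamino on a saturated chain carbon bound to an aromatic carbon gives a 1.2-fold lower number from compound 1 to compound 4 (0.09 log units; within the scatter) as the first measured step at this place. The open dimethylamino and the six-membered non-aromatic ring of piperidin-1-yl therefore cannot be told apart on this read-out, so closing the amine into this ring leaves the result unchanged within the scatter, while the rest of the molecule stays the same. No measured property of either group bears on this result, so the finding stays a plain observation on this single pair.

What the compounds shown leave open is whether other groups on this chain carbon, such as morpholin-4-yl, piperazin-1-yl, a primary amine or a carboxylic acid, would also stay within the scatter of compound 1. For the compounds shown here, they also leave open whether a longer chain carrying the piperidin-1-yl would keep the number where it stands, since this one pair tests only a single swap of one amine for another on a one-carbon link.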